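Methyl for chloro on the phenoxy ring of a thiosemicarbazone

This account rests on a few compounds, and the source may have more. Where it says the series, first, only, none or still open, it means among the compounds named here.

Compound 1 `S=C(N/N=C/c1ccc(Oc2ccc(Cl)cc2)cc1)Nc1ccccc1`: 5.52
Compound 2 `S=C(N/N=C/c1ccc(Oc2ccc(Cl)cc2)cc1)Nc1ccc(Br)cc1`: 6.24
Compound 3 `Cc1cc(Oc2ccc(/C=N/NC(=S)Nc3ccc(Br)cc3)cc2)ccc1Cl`: 7.89

In a physicochemical assay for lipophilicity, in phosphate buffer, measured as octanol-water partition, with a stated time of 24 h (a lower number here means a more polar compound, a higher number a more lipophilic compound), compound 1 gives the lowest of the three numbers. Its nearest neighbour is compound 2, a number 0.72 log units higher from compound 1 to compound 2 (beyond the scatter); compound 3 lies furthest away with 7.89, whereas compound 1 gives 5.52. Compound 4 `Cc1ccc(Oc2ccc(/C=N/NC(=S)Nc3ccccc3)cc2)cc1` differs from compound 1 in one place: methyl in place of chloro on an aromatic carbon. Among the compounds with values here, no measured step exchanges chloro for methyl directly. The closest comparisons are the bromo-for-hydrogen step, a number 0.72 log units higher from compound 1 to compound 2 (beyond the scatter), and the methyl-for-hydrogen step, a number 1.65 log units higher from compound 2 to compound 3 (beyond the scatter); both point upward, but here one group replaces another of comparable size, so only a small shift, if any beyond the scatter, is expected in this assay. Compound 4 is therefore estimated at 5.4, between 4.7 and 6.1, an expected step of a number 0.12 log units lower from compound 1 to compound 4 (within the scatter).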

Compound 4, partition coefficient: 5.39
Compound 4: middle estimate off by 0.01 log units, on the high side; measured number inside the range.
By their numbers in this assay, from the lowest: compounds 4 and 1 (each within the scatter of the next); then compound 2; then compound 3.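

In this assay, methyl in place of chloro on the phenoxy ring gives a number 0.13 log units lower from compound 1 to compound 4 (within the scatter), so this exchange at a site para to a large group does not separate the two compounds. The earlier steps shown here, each replacing a hydrogen, both lay beyond the scatter, whereas this first exchange of one substituent for another does not. Nothing available accounts for this result. As far as these compounds go, it remains open whether an amine, a carboxylic acid or a longer chain at this position would also stay within the scatter. From the compounds shown here alone, whether methyl for chloro behaves the same way with the bromo group of compound 2 also remains open.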